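Swapping one aryl group on a nitro-bearing compound

This account rests on a few compounds, and the source may have more. Where it says the series, first, only, none or still open, it means among the compounds named here.

Values so far in a functional assay on QG-56 cells (Homo sapiens) for antiproliferative activity; a higher number here means a weaker inhibitor, a lower number a stronger inhibitor

Compound 1 `Cn1cncc1C(O)(c1ccc(C#N)cc1)c1cc2cc([N+](=O)[O-])cc(-c3ccc(F)cc3)c2o1` gives 158 nM
Compound 2 `Cn1cncc1C(O)(c1ccc(Cl)cc1)c1cc2cc(C(=O)NN3CCOCC3)cc(-c3ccccc3)c2o1` gives 73.6 nM

Of these two measured compounds, compound 1 stands higher, and a higher number here means a weaker inhibitor. The gap to compound 2 lies beyond the usual scatter of repeated measurements. The two compounds differ in several places, however, so their gap cannot be pinned on any single group.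

The next compound to be tested is compound 3 `Cn1cncc1C(O)(c1ccc(C#N)cc1)c1cc2cc([N+](=O)[O-])cc(-c3cccc(C#N)c3)c2o1`, which keeps the core of compound 1 and changes one group. It carries 3-cyanophenyl in place of 4-fluorophenyl on an aromatic carbon and so gains a nitrile. Among the compounds with values here, no measured pair isolates this kind of swap, so the data offer no direct guide to its effect. The best anchor is compound 1 at 158 nM. The two compounds share everything else. Expected in this assay is no step beyond the scatter (a 1.2-fold higher number from compound 1 to compound 3 (0.08 log units; within the scatter)). The estimated value for compound 3 is 190 nM (expected range 70 nM to 520 nM).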

Compound 3, half-maximal inhibitory concentration: 22.9 nM
Compound 3: middle estimate off by 8.3-fold (0.92 log units), on the high side; the whole stated range lies above it.
By their numbers in this assay, from the lowest: compound 3; then compound 2; then compound 1.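

In this assay, within the data shown here, the swap of 4-fluorophenyl for 3-cyanophenyl brings a 6.9-fold lower number from compound 1 to compound 3 (0.84 log units; beyond the scatter) and gives the first view of a change at a single place. Compound 1 and compound 3 share everything else, so this step can be tied to this aryl group, on the aromatic carbon meta to the nitro group. The choice of aryl group here can therefore shift the number well beyond the usual scatter, and in this pair the 3-cyanophenyl compound is the stronger inhibitor. No measurement shown here accounts for the gain, which remains an observation without a stated cause.

The swap removes a fluorine and adds a nitrile, and the two groups also carry different numbers in their names, so this single pair cannot separate the identity of the group from where it sits on the phenyl ring; a comparison with 4-cyanophenyl or 3-fluorophenyl at this place would pull the two apart. Going by these compounds, it also remains open whether a step of this size would hold if an amine stood in place of the nitro group.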